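A Stereocentre Flip Under Three Limits

This account rests on a few compounds, and the source may have more. Where it says the series, first, only, none or still open, it means among the compounds named here.

Measured compounds:
compound 1, `C=C(C)CCC1(C=C(C)C)C(=O)C2=C(O)[C@H](C)[C@@H](C)OC2=C(C(CC(=O)O)c2ccccc2)C1=O` — > 20 ug/mL
compound 2, `C=C(C)[C@@H]1C[C@@H](CC2(CC=C(C)C)C(=O)C(C(CC(=O)O)c3ccccc3)=C3O[C@H](C)[C@@H](C)C(=O)C3=C2O)C1(C)C` — > 20 ug/mL
compound 3, `C=C(C)CCC1(C=C(C)C)C(=O)C2=C(O)[C@H](C)[C@H](C)OC2=C(C(CC(=O)O)c2ccccc2)C1=O` — > 20 ug/mL

In a functional assay on cells for cytotoxicity (a higher number here means a weaker inhibitor, a lower number a stronger inhibitor), compound 1 gives > 20 ug/mL, which is a limit of the assay and not a number. Compound 3 likewise gives > 20 ug/mL in this assay, again a limit. The step that the two limits leave unreadable from compound 1 to compound 3 therefore cannot be read, because the limit of > 20 ug/mL in this assay, at which 3 of the 3 values shown sit, sets both ends of it at the same limit; the two compounds differ only in that a stereocentre at a saturated ring carbon is drawn R in compound 1 and S in compound 3, as noted in the fact that one of compounds 1 and 3 is drawn with a defined configuration and the other without, at the place where they differ.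

Compound 2 stands no differently: in this assay compound 2 gives > 20 ug/mL, a limit, so all three values shown sit at that limit and none of them offers a measurable step.

Compound 4, `C=C(C)[C@@H]1C[C@@H](CC2(CC=C(C)C)C(=O)C(C(CC(=O)O)c3ccccc3)=C3O[C@@H](C)[C@@H](C)C(=O)C3=C2O)C1(C)C`, differs from compound 2 only in this way: the two compounds have the same atoms and bonds; at least one stereo element is drawn with a configuration in one of them and without one in the other: 1 of 6 stereo elements differ; a stereocentre at a saturated ring carbon is drawn R in compound 2 and S in compound 4. For the measured compounds named here, the only comparable change, from compound 1 to compound 3, moved between two limits and gave no readable size. Nothing therefore points to a step beyond the scatter in either direction, and compound 4 is expected to remain at the limit, so that a step that the limit leaves unreadable from compound 2 to compound 4 is estimated as no change beyond the scatter. Compound 4 is accordingly estimated at 30 ug/mL, within a range from 12 ug/mL to 100 ug/mL.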

Compound 4, half-maximal inhibitory concentration: > 20 ug/mL
Compound 4 ended at the assay's limit; the forecaster's own chance of this, stated with the estimate: 85%; the middle value is on the limit's open side.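

In this assay compound 4 gives > 20 ug/mL, a limit of the assay and not a number. Compound 2 sits at the same limit, so no step can be read between compound 2 and compound 4. The compounds shown leave open whether drawing the saturated ring stereocentre R or S matters in this assay at all, as every value rests on one limit: the limit of > 20 ug/mL in this assay, at which 4 of the 4 values shown sit.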